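A Hydroxyl in Place of a Methyl on a Weak Series

The source may report more compounds than this note shows. Statements on the series, on what has been measured and on what is new or still open speak of the compounds shown alone.

Three compounds share a sulfonamide link between two aromatic parts, and all were tested in an assay on cells for inhibition of HSP60/HSP10 (Homo sapiens), with a stated time of 60 min; on this read-out lower numbers stand for stronger inhibition and higher numbers for weaker inhibition. Compound 1 `Cc1ccc(S(=O)(=O)Nc2ccc(-c3nc4ccccc4o3)cc2)cc1` reaches only the limit of the assay, giving > 100000 nM in this assay. Compound 2 `Cc1ccccc1S(=O)(=O)Nc1ccc2oc(-c3ccccc3)nc2c1` likewise reaches only the limit, giving > 100000 nM in this assay. Among the compounds with values here, compound 3 `O=[N+]([O-])c1cc(S(=O)(=O)Nc2ccc(-c3nc4ccccc4o3)cc2)ccc1Cl` is the one member with a number, giving 17000 nM in this assay. So compound 2 stands at the limit, a point where two of the three results sit, as stated in the limit of > 100000 nM in this assay, at which 2 of the 3 values shown sit; its true strength is unknown beyond being weak.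

The next compound, compound 4 `O=S(=O)(Nc1ccc2oc(-c3ccccc3)nc2c1)c1cccc(O)c1`, keeps the core of compound 2 and changes one group: 3-hydroxyphenyl in place of 2-methylphenyl on a sulfonyl sulfur. Within the data shown here, no measured pair differing in a single place exists here, so the size of this step cannot be read from any neighbour. Since compound 2 gives only a limit, the step could be anything from none beyond the scatter to a modest gain, and compound 3 shows that a number below the limit is possible in this series.

Compound 4 is expected to give about 60000 nM, with a plausible range from 15000 nM to 200000 nM. The expected change in this assay from that estimate is an at least 1.6-fold lower number from compound 2 to compound 4 (0.22 log units; that floor lies within the scatter).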

Compound 4, half-maximal inhibitory concentration: 76000 nM
Compound 4: middle estimate off by 1.3-fold (0.10 log units), on the low side; low and high end bracket the measured number.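

Replacing 2-methylphenyl with 3-hydroxyphenyl on a sulfonyl sulfur gives this position a measured number instead of a limit, showing that the core of compound 2 can register in this assay with this group in place. The change amounts to an at least 1.3-fold lower number from compound 2 to compound 4 (0.11 log units; that floor lies within the scatter), so this result alone does not establish a real gain, although the true difference could be larger. The step can be given only as a floor because compound 2 has a limit rather than a number: the limit of > 100000 nM in this assay, at which 2 of the 4 values shown sit.

Going by these compounds, it remains open whether the hydroxyl itself or the loss of the methyl accounts for the measured number, a question that a plain phenyl on the sulfonyl sulfur could help to settle. Also open, on these data alone, is how a methoxy group, an amine or a carboxylic acid would behave in place of the hydroxyl, and whether any of them would give a clear step beyond the usual scatter of the read-out.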